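The compounds below may be only part of what the source reports. "The series", "measured", "known", "first", "only" and "open" are said of these compounds alone.

Compound 1 `O=C(Nc1cccc(Cl)c1)O/N=C(\C1CCCCC1)C(Cc1ccncc1)C1CCCCC1` carries a pyridin-4-yl group on one arm of the shared core. In an assay on isolated protein for displacement of a labelled ligand from metabotropic glutamate receptor 5 (Rattus norvegicus) (on this read-out higher numbers stand for weaker inhibition and lower numbers for stronger inhibition), compound 1 gives 117 nM, the highest of the three measured numbers. Compound 3 `COc1cccc(NC(=O)O/N=C(\C2CCCCC2)C(Cc2cccs2)C2CCCCC2)c1`, which bears a methoxy group on an aromatic carbon, gives 88 nM, and the gap between compound 1 and compound 3 lies within the scatter. Compound 2 `Cc1cccc(NC(=O)O/N=C(\C2CCCCC2)C(Cc2cccs2)C2CCCCC2)c1`, with a methyl group on that aromatic carbon, gives 8.3 nM; the gap from compound 1 to compound 2 lies beyond the scatter. Among the measured compounds shown here, the single clean step among the measured compounds, an 11-fold higher number from compound 2 to compound 3 (1.03 log units; beyond the scatter), concerns the carbamate end of the molecule and leaves the other arm untouched.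

Compound 4 `CN(C)c1ccc(CC(/C(=N/OC(=O)Nc2cccc(Cl)c2)C2CCCCC2)C2CCCCC2)cc1` differs from compound 1 by 4-(dimethylamino)phenyl in place of pyridin-4-yl on a saturated chain carbon, two bonds along the chain from a carbon with a double bond to nitrogen and a saturated ring carbon. For the measured compounds named here, no measured step speaks to this arm: compounds 2 and 3 carry a different group there, but they also differ from compound 1 on an aromatic carbon elsewhere, so no clean comparison exists. The direction of the change cannot be read from the data. With nothing to lean on, compound 4 is estimated at 90 nM, within a range from 20 nM to 400 nM. This expectation corresponds to a 1.3-fold lower number from compound 1 to compound 4 (0.11 log units; within the scatter), a step not confidently beyond the scatter.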

Compound 4, inhibition constant: > 1000 nM
Compound 4 was reported as a limit; the forecaster's own chance of this, stated with the estimate: 5%; at least 11-fold (1.04 log units) between middle value and limit.
By their numbers in this assay, from the lowest: compound 2; then compounds 3 and 1 (each within the scatter of the next). At a limit, above all of these: compound 4.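

Among the compounds shown here, until now no clean step spoke to this arm of the shared core. With the carbamate end held fixed, 4-(dimethylamino)phenyl in place of pyridin-4-yl on a saturated chain carbon gives an at least 8.5-fold higher number from compound 1 to compound 4 (0.93 log units; beyond the scatter) in this assay. This shows that the arm alone can shift the number towards weaker inhibition, and that this position does not treat these two aromatic groups alike, which compound 1, compound 2 and compound 3 could not show. The full size of the step stays unknown because the result for compound 4 is a limit of the assay and not a number: the limit of > 1000 nM in this assay, at which 1 of the 4 values shown sits.

The compounds shown do not separate the two parts of the change, the ring of carbon only and the dimethylamino group; a plain phenyl or a 4-methoxyphenyl on the same carbon would bear on that. They also leave open how the arm carried by compound 2 and compound 3 would read with the carbamate end of compound 1, and whether a smaller amine such as methylamino on the ring would give a number that can be read.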